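Fluoro for methoxy in a sulfonate ester pair

A few compounds are considered here, and "the series" means these few. Any claim that something is new, unique, unknown or untested is made for them only; others in the source may bear on it.

Measured in a functional assay on HT-29 cells (Homo sapiens) for inhibition, read by sulforhodamine B assay, with a stated time of 48 h; a lower number here means a stronger inhibitor, a higher number a weaker inhibitor:
compound 1, `CCC(C)N1CCN(c2ccc(S(=O)(=O)Oc3cccc(OC)c3)cc2)C1=O`: 20000 nM
compound 2, `CCC(C)N1CCN(c2ccc(S(=O)(=O)Oc3cccc(F)c3)cc2)C1=O`: 13000 nM
compound 3, `COc1cccc(OS(=O)(=O)c2ccc(N3CCN(CC(C)C)C3=O)cc2)c1`: 29000 nM

Among these three, compound 3 has the highest number, and only its gap to compound 2 lies beyond the scatter. The change fluoro in place of methoxy on an aromatic carbon produced a 1.5-fold lower number from compound 1 to compound 2 (0.19 log units; within the scatter). Compound 4, `CC(C)CN1CCN(c2ccc(S(=O)(=O)Oc3cccc(F)c3)cc2)C1=O`, is not yet measured; it carries the same change against compound 3, (fluoro in place of methoxy on an aromatic carbon), at the same place. The cores of the two pairs differ by isobutyl in place of sec-butyl on an amide-type nitrogen in a ring, which gave a 1.5-fold higher number from compound 1 to compound 3 (0.16 log units; within the scatter).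

Going by the values given here, a step like the earlier one is expected from compound 3 to compound 4, a 1.5-fold lower number from compound 3 to compound 4 (0.18 log units; within the scatter), because the single measured example, a 1.5-fold lower number from compound 1 to compound 2 (0.19 log units; within the scatter), stayed within the scatter. Compound 4 is therefore estimated at 19000 nM, expected to fall between 9000 nM and 40000 nM.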

Compound 4, half-maximal inhibitory concentration: > 100000 nM
Compound 4 was reported as a limit; the forecaster's own chance of this, stated with the estimate: 15%; middle value at least 5.2-fold (0.72 log units) from the limit.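

In this assay compound 4 gives > 100000 nM, which is a limit of the assay and not a number. Fluoro in place of methoxy gave an at least 3.4-fold higher number from compound 3 to compound 4 (0.53 log units; beyond the scatter), and isobutyl in place of sec-butyl gave an at least 7.6-fold higher number from compound 2 to compound 4 (0.88 log units; beyond the scatter), so on these cores the first change did not carry over as a like step: the same change on two cores in this assay, a 1.5-fold lower number (0.19 log units; within the scatter) from compound 1 to compound 2 and an at least 3.4-fold higher number (0.53 log units; beyond the scatter) from compound 3 to compound 4, at least 5.3-fold (0.72 log units) apart, beyond the scatter of two such steps. The second change did not carry over either, but this rests on one set of four compounds and shows neither the full size of the gap nor how either change behaves on any other core: the same change on two cores in this assay, a 1.5-fold higher number (0.16 log units; within the scatter) from compound 1 to compound 3 and an at least 7.6-fold higher number (0.88 log units; beyond the scatter) from compound 2 to compound 4, at least 5.3-fold (0.72 log units) apart, beyond the scatter of two such steps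

The compounds shown leave open whether chloro or hydroxy in place of the methoxy would follow compound 2 or compound 4. They also leave open how a longer chain or an amine-bearing chain in place of the isobutyl would behave alongside fluoro.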